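The source may report more compounds than this note shows. Statements on the series, on what has been measured and on what is new or still open speak of the compounds shown alone.

The measured compounds:

Compound 1, `COc1ccc(-c2cc(N)c(C(=O)c3cc(OC)c(OC)c(OC)c3)s2)cc1OC`, 72 nM
Compound 2, `COc1cc(C(=O)c2sc(-c3ccc([N+](=O)[O-])cc3)cc2N)cc(OC)c1OC`, 64 nM
Compound 3, `COc1cc(C(=O)c2sc(-c3ccc(F)cc3)cc2N)cc(OC)c1OC`, 16 nM

In a functional assay on FM3A cells (Mus musculus) for antiproliferative activity (on this read-out higher numbers stand for weaker inhibition and lower numbers for stronger inhibition), compound 1 gives the highest of the three numbers. Its nearest neighbour is compound 2, with a 1.1-fold lower number from compound 1 to compound 2 (0.05 log units; within the scatter), a difference that stays within the scatter. Compound 3 lies furthest away, with a 4.5-fold lower number from compound 1 to compound 3 (0.65 log units; beyond the scatter). Between the two aryl analogues the difference is a 4.0-fold lower number from compound 2 to compound 3 (0.60 log units; beyond the scatter).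

Compound 4, `COc1cc(C(=O)c2sc(-c3ccc(C(F)(F)F)cc3)cc2N)cc(OC)c1OC`, has not yet been measured. It differs from compound 1 in one place: 4-(trifluoromethyl)phenyl in place of 3,4-dimethoxyphenyl on an aromatic carbon.

Among the compounds with values here, two measured steps bear on this change, since both replace the 3,4-dimethoxyphenyl of compound 1 with a phenyl carrying a single substituent in the 4-position. The nitro analogue, compound 2, moved within the scatter; the fluoro analogue, compound 3, moved modestly to a lower number. With only these two cases, no firm pattern can be claimed, and the outcomes spread from no change to a modest gain. A step of similar size, toward a lower number, is therefore expected for compound 4, though it may also stay within the scatter.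

Compound 4 is estimated to give 40 nM in this assay, between 15 nM and 110 nM, which would mean a 1.8-fold lower number from compound 1 to compound 4 (0.26 log units; within the scatter) as the expected step.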

Compound 4, half-maximal inhibitory concentration: 540 nM
The estimate for compound 4 lay 14-fold (1.13 log units) below the measured number; measured number outside the range, above it.
By their numbers in this assay, from the lowest: compound 3; then compounds 2 and 1 (each within the scatter of the next); then compound 4.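

In this assay, the change to 4-(trifluoromethyl)phenyl gave a 7.5-fold higher number from compound 1 to compound 4 (0.88 log units; beyond the scatter), which shows that replacing 3,4-dimethoxyphenyl at this carbon can also raise the number, whereas compound 3 had so far shown only a lower one. The single group on the phenyl ring decides the outcome here: trifluoromethyl in place of fluoro gave a 34-fold higher number from compound 3 to compound 4 (1.53 log units; beyond the scatter), the largest step among these compounds, and trifluoromethyl in place of nitro gave an 8.4-fold higher number from compound 2 to compound 4 (0.93 log units; beyond the scatter). Nothing available explains why trifluoromethyl separates so sharply from fluoro and nitro.

The compounds shown leave open whether the higher number belongs to trifluoromethyl alone or extends to other groups on the phenyl ring, such as methyl, chloro, a single methoxy or an amine. On these data alone, all four compounds also keep the rest of the core of compound 1 unchanged, so it remains open whether the same order would hold with a hydroxyl or a methyl group in place of the amino group.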